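From fluoro to chloro on a shared core

The source may report more compounds than this note shows. Statements on the series, on what has been measured and on what is new or still open speak of the compounds shown alone.

Values measured so far in an ADME assay for permeability, using PAMPA, with a stated time of 10 h, tested at 100 ug/mL (a higher number here means that the compound crosses the layer faster, a lower number that the compound crosses the layer more slowly), are these
Compound 1 `Oc1cccc2ccc(-c3cc4ccccc4[nH]3)nc12` gives 8 10^-6 cm/s
Compound 2 `Oc1cccc2ccc(-c3cc4cc(F)ccc4[nH]3)nc12` gives 10.6 10^-6 cm/s

Going by the values given here, compound 1 has a hydrogen where compound 2 carries fluoro, and compound 2 at 10.6 10^-6 cm/s sits within the usual scatter of compound 1, the only other measured compound, so neither can be ranked above the other. The next compound is compound 3 `Oc1cccc2ccc(-c3cc4cc(Cl)ccc4[nH]3)nc12` with chloro in place of fluoro on an aromatic carbon and the rest of the structure unchanged.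

Among the compounds with values here, only one measured step bears on this change. The exchange of hydrogen for fluoro gave a 1.3-fold higher number from compound 1 to compound 2 (0.12 log units; within the scatter) and so stayed small. Within the data shown here, no chloro compound has been measured yet, which makes that single step a thin guide. On that evidence, a move in this assay beyond the scatter is not expected, and no firm direction can be argued. The expected result is a 1.0-fold higher number from compound 2 to compound 3 (0.02 log units; within the scatter) and nothing larger. For compound 3 the estimate is 11 10^-6 cm/s with an expected range from 5.5 10^-6 cm/s to 22 10^-6 cm/s in this measurement.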

Compound 3, apparent permeability: 9.8 10^-6 cm/s
For compound 3 the middle estimate is 1.1-fold (0.05 log units) above the measured one; low and high end bracket the measured number.
By their numbers in this assay, from the lowest: compounds 1, 3 and 2 (each within the scatter of the next).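

In this assay, chloro in place of fluoro gives a 1.1-fold lower number from compound 2 to compound 3 (0.03 log units; within the scatter) and chloro in place of hydrogen gives a 1.2-fold higher number from compound 1 to compound 3 (0.09 log units; within the scatter), so neither step leaves the usual scatter of repeated measurements. Going by these compounds alone, until now, fluoro was the only group compared with hydrogen at this aromatic carbon, meta to a fused ring and para to a fused ring; with chloro as a second halogen, the three compounds still cannot be ranked by this read-out, and this holds for these three groups at this one place only. Nothing available here gives a measured reason for how close these numbers lie, so the result stands as a plain observation without an explanation.

On these data alone, it remains open whether bromo, or a group of a quite different kind such as an amine, a carboxylic acid or a longer chain, would move the number beyond the scatter at this same carbon. As far as these compounds go, it is also open whether chloro or fluoro would give an equally small step on any other carbon of the shared core, since all three compounds vary at this single place.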